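Quinazoline piperazine amides and a sulfonyl variant at alpha-1

The source may hold more compounds than are shown below. What is called first, only, known or untested is meant among the compounds shown, and "the series" means these compounds.

Measured compounds:
compound 1, `COc1cc2nc(N3CCN(C(=O)COc4ccccc4)CC3)nc(N)c2cc1OC`, 12.6 nM
compound 2, `COc1cc2nc(N3CCN(C(=O)c4ccc(N=C=S)c(I)c4)CC3)nc(N)c2cc1OC`, 51.3 nM

Both compounds were characterised in an assay for binding affinity to Adrenergic receptor alpha-1 (Rattus norvegicus); a higher number here means a weaker inhibitor, a lower number a stronger inhibitor. Compound 1, with a (phenoxymethyl)carbonyl group on the ring nitrogen of the shared core, gives 12.6 nM, the lower of the two numbers. For the measured compounds named here, compound 2 carries a different carbonyl substituent, and in this assay compound 2 gives 51.3 nM; the change a 4.1-fold higher number from compound 1 to compound 2 (0.61 log units; beyond the scatter) is the only step available for comparison.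

The unmeasured compound 3 is `COc1cc2nc(N3CCN(S(=O)(=O)c4cccs4)CC3)nc(N)c2cc1OC`. It differs from compound 1 in that ((thiophen-2-yl)sulfonyl in place of (phenoxymethyl)carbonyl on an amine nitrogen in a ring). Going by the values given here, the one measured step bears on this change only loosely: it shows that exchanging the group on the ring nitrogen of compound 1 for another aromatic-bearing group weakened binding modestly. Nothing measured addresses a sulfonyl in place of a carbonyl, so the expectation for compound 3 is uncertain. On balance a modest weakening is expected, a 2.4-fold higher number from compound 1 to compound 3 (0.38 log units; beyond the scatter), in the same direction as from compound 1 to compound 2. Compound 3 is therefore expected to give about 30 nM in this assay, within a range from 8 nM to 120 nM.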

Compound 3, half-maximal inhibitory concentration: 33.9 nM
Beside the measured number, compound 3's estimate is 1.1-fold (0.05 log units) below it; the range from low to high includes it.
By their numbers in this assay, from the lowest: compound 1; then compounds 3 and 2 (each within the scatter of the next).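

Compound 3 shows that the amine nitrogen in the ring need not carry a carbonyl for binding to persist in this assay, since (thiophen-2-yl)sulfonyl in place of (phenoxymethyl)carbonyl gives a 2.7-fold higher number from compound 1 to compound 3 (0.43 log units; beyond the scatter), a modest step that is still beyond the scatter. This single step changes the carbonyl to a sulfonyl and also replaces a six-membered aromatic ring of carbon only with a five-membered aromatic ring with one hetero atom, so its size cannot be divided among these parts. Compound 1 remains the lowest of the three, with its steps to both others beyond the scatter, while the printed values of compound 3 and compound 2 lie within the scatter of each other; no supporting evidence accounts for these differences.

From the compounds shown here alone, it remains open whether the sulfonyl or the thiophen-2-yl group matters more, a question that a phenylsulfonyl group or a (thiophen-2-yl)carbonyl group on the same nitrogen could help separate. Also open, going by these compounds, is how this position responds to groups without an aromatic ring, such as an acetyl group, an aminoethyl chain or a carboxylic acid.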